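Sulfonyl aryl variation in a cytotoxicity series

The source may hold more compounds than are shown below. What is called first, only, known or untested is meant among the compounds shown, and "the series" means these compounds.

Measured so far:
compound 1, `CCCc1nc2c(C)cc(-c3nc4ccccc4n3C)cc2n1S(=O)(=O)c1ccccc1` — 23800 nM
compound 2, `CCCc1nc2c(C)cc(-c3nc4ccccc4n3C)cc2n1S(=O)(=O)c1ccc(Cl)cc1` — 21400 nM

In a functional assay on HeLa cells (Homo sapiens) for cytotoxicity, read by MTT assay (on this read-out lower numbers stand for stronger inhibition and higher numbers for weaker inhibition), compound 2 gives 21400 nM, the lower of the two numbers, with compound 1 at 23800 nM next to it; the step of a 1.1-fold lower number from compound 1 to compound 2 (0.05 log units; within the scatter) lies within the scatter. Compound 3, `CCCc1nc2c(C)cc(-c3nc4ccccc4n3C)cc2n1S(=O)(=O)c1ccccc1Br`, is not yet measured. It differs from compound 2 by 2-bromophenyl in place of 4-chlorophenyl on a sulfonyl sulfur. Among the compounds with values here, the only measured step, a 1.1-fold lower number from compound 1 to compound 2 (0.05 log units; within the scatter), concerns a change on the same aryl group and did not move the number beyond the scatter, so it offers a weak precedent at best. Within the data shown here, no other step bears on this change. On that basis no step beyond the scatter is expected for a 1.0-fold higher number from compound 2 to compound 3 (0.01 log units; within the scatter) in this assay. Among the measured compounds shown here, compound 3 is therefore estimated at 22000 nM, with a range of 9000 nM to 55000 nM, the range kept wide since a halogen in a different position on the ring has no measured counterpart here.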

Compound 3, half-maximal inhibitory concentration: > 50000 nM
Compound 3: a limit, no number; the forecaster's own chance of this, stated with the estimate: 10%; middle value at least 2.2-fold (0.35 log units) from the limit.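

In this assay compound 3 stands at a limit of the assay, not a number: the limit of > 50000 nM in this assay, at which 1 of the 3 values shown sits.

The aryl group on the sulfonyl sulfur can therefore move the read-out: 2-bromophenyl gives an at least 2.3-fold higher number from compound 2 to compound 3 (0.36 log units; beyond the scatter) and also an at least 2.1-fold higher number from compound 1 to compound 3 (0.32 log units; beyond the scatter) and both steps lie beyond the scatter. The earlier change gave a 1.1-fold lower number from compound 1 to compound 2 (0.05 log units; within the scatter) and so showed no such movement for 4-chlorophenyl.

On these data alone, the full size of both new steps stays open, and 2-bromophenyl differs from 4-chlorophenyl in both the halogen and its place on the ring, so the two cannot be told apart without 2-chlorophenyl and 4-bromophenyl. As far as these compounds go, how an amine on this aryl ring would read also remains open.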